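The source may hold more compounds than are shown below. What is called first, only, known or untested is meant among the compounds shown, and "the series" means these compounds.

Measured compounds:
compound 1 `Cc1cc(Nc2cc(-c3ccccc3)[nH]n2)n2nc(SCCCc3ccccc3)nc2n1` — 5030 nM
compound 2 `Cc1cc(Nc2ccn(Cc3nc(C)c4ccccc4n3)n2)n2nc(SCc3ccc(Br)cc3)nc2n1` — 5450 nM

In a functional assay on PC-9 cells (Homo sapiens) for inhibition, read by MTT assay, with a stated time of 72 h (a lower number here means a stronger inhibitor, a higher number a weaker inhibitor), compound 1 gives 5030 nM, the lowest of the two numbers; compound 2 gives 5450 nM, which lies within the scatter of compound 1, so the two are not separable. Compound 3 `CCCSc1nc2nc(C)cc(Nc3cc(-c4ccccc4)[nH]n3)n2n1` is the next entry and differs from compound 1 by hydrogen in place of phenyl on a saturated chain carbon, three bonds along the chain from a sulfur. Among the compounds with values here, no measured pair covers this change, so its effect is unknown from the data. The step of a 1.6-fold higher number from compound 1 to compound 3 (0.20 log units; within the scatter) is expected to be a modest rise in the number, at most slightly beyond the scatter. Compound 3 is estimated at 8000 nM, with an expected range from 2500 nM to 25000 nM.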

Compound 3, half-maximal inhibitory concentration: > 50000 nM
Compound 3 gave a limit, no number; the forecaster's own chance of this, stated with the estimate: 20%; at least 6.2-fold (0.79 log units) between middle value and limit.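

In this assay, within the data shown here, hydrogen in place of phenyl on a saturated chain carbon, three bonds along the chain from a sulfur, is the first change that can be read, and it gives an at least 9.9-fold higher number from compound 1 to compound 3 (0.99 log units; beyond the scatter). Cutting 3-phenylpropyl back to propyl is therefore not a neutral change at this position. The value of compound 3 is a limit, not a number: the limit of > 50000 nM in this assay, at which 1 of the 3 values shown sits.

On these data alone, whether cyclohexyl or an amine at the chain end could stand in for the phenyl remains open. So does how the number moves with a longer chain carrying the phenyl.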